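Furan for Thiophene: a Single Ring Swap

This account rests on a few compounds, and the source may have more. Where it says the series, first, only, none or still open, it means among the compounds named here.

Compound 1 `O=c1[nH]cnc2c1c(-c1cccs1)cn2[C@@H]1O[C@H](CO)[C@@H](O)[C@H]1O` was tested in a functional assay on HCT-116 cells (Homo sapiens), read by MTT assay, with a stated time of 72 h; on this read-out lower numbers stand for stronger inhibition and higher numbers for weaker inhibition. In this assay compound 1 gives only a limit, > 20000 nM, so its inhibition is not resolved into a number. Compound 2 `Cc1nc(N)c2c(-c3ccccc3)cn([C@@H]3O[C@H](CO)[C@@H](O)[C@H]3O)c2n1` is the other compound measured. In this assay compound 2 likewise reaches only a limit, > 100000 nM. Compound 1 therefore stands where both values shown sit, at a limit rather than at a number: one value sits at the limit of > 20000 nM in this assay, at which 1 of the 2 values shown sits, and the other at the limit of > 100000 nM in this assay, at which 1 of the 2 values shown sits. Compound 3 `O=c1[nH]cnc2c1c(-c1ccco1)cn2[C@@H]1O[C@H](CO)[C@@H](O)[C@H]1O` differs from compound 1 in one place: furan-2-yl in place of thiophen-2-yl on an aromatic carbon. Among the measured compounds shown here, no step between measured compounds is known here, so the size of this change can only be expected, and nothing in the two limits points toward stronger inhibition. Compound 3 is expected to give 30000 nM, in a range from 8000 nM to 150000 nM. The expected step is a step that the limit leaves unreadable from compound 1 to compound 3, nothing beyond the scatter.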

Compound 3, half-maximal inhibitory concentration: 18300 nM
Beside the measured number, compound 3's estimate is 1.6-fold (0.21 log units) above it; the range from low to high includes it.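

In this assay, compound 3 gives 18300 nM, so this position now carries a resolved number. Compound 1 and compound 2 gave only limits. Placing furan-2-yl in place of thiophen-2-yl on this aromatic carbon keeps the heavy-atom and hydrogen-bond acceptor counts printed for the two groups and gives an at least 1.0-fold lower number from compound 1 to compound 3 (0.03 log units; that floor lies within the scatter). That step is only a floor because the value of compound 1 is a limit: the limit of > 20000 nM in this assay, at which 1 of the 3 values shown sits.

As far as these compounds go, the true distance between compound 1 and compound 3 therefore stays open, and the steps involving compound 2 cannot be read. The compounds shown also leave open how this assay would respond to an amine, a carboxylic acid or a longer alkyl chain on the same aromatic carbon.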